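The source may hold more compounds than are shown below. What is called first, only, known or untested is meant among the compounds shown, and "the series" means these compounds.

Of the compounds shown here, three of a shared core have been tested so far in a functional assay on A549 cells (Homo sapiens) for cytotoxicity, read by MTT assay, with a stated time of 48 h; a higher number here means a weaker inhibitor, a lower number a stronger inhibitor. Compound 1 `N#Cc1ccc(Cn2cc(COc3ccc4c(=O)ccoc4c3)nn2)cc1` reaches only the limit of the assay, > 100000 nM, and no number. Compound 2 `O=c1ccoc2cc(OCc3cn(Cc4cccc(F)c4)nn3)ccc12` likewise reaches only the limit, > 100000 nM. Among the compounds with values here, compound 3 `O=c1ccoc2cc(OCc3cn(Cc4cccc(Cl)c4)nn3)ccc12` is the one compound with an actual number in this assay, 13700 nM, so it stands alone as the sole readable value among the three, with the other two sitting at the limit of > 100000 nM in this assay, at which 2 of the 3 values shown sit.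

Compound 4 `O=c1ccoc2cc(OCc3cn(Cc4ccc(Br)cc4)nn3)ccc12` differs from compound 3 in one place: 4-bromophenyl in place of 3-chlorophenyl on a saturated chain carbon bound to an aromatic nitrogen.

Two measured steps speak to this change. From the fluoro compound to the chloro compound the step is an at least 7.2-fold lower number from compound 2 to compound 3 (0.86 log units; beyond the scatter), and from the cyano compound it is an at least 7.2-fold lower number from compound 1 to compound 3 (0.86 log units; beyond the scatter); the step that the two limits leave unreadable from compound 1 to compound 2 cannot be read. So swapping one halogen for another on this benzyl group has moved the number well beyond the scatter, and bromo is, like chloro, a halogen. The expectation is that compound 4 keeps a measurable number and changes only modestly, a step of a 1.4-fold lower number from compound 3 to compound 4 (0.14 log units; within the scatter) in this assay.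

Compound 4 is therefore estimated at 10000 nM, expected to fall between 3000 nM and 40000 nM.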

Compound 4, half-maximal inhibitory concentration: > 100000 nM
Compound 4 was reported as a limit; the forecaster's own chance of this, stated with the estimate: 15%; at least 10-fold (1.00 log units) between middle value and limit.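

In this assay, the change from 3-chlorophenyl to 4-bromophenyl on a saturated chain carbon bound to an aromatic nitrogen gives an at least 7.2-fold higher number from compound 3 to compound 4 (0.86 log units; beyond the scatter), so the earlier idea that a heavier halogen on this benzyl group keeps a readable number does not hold for compound 4. Until now, the readable result could be set against only a fluoro and a cyano compound, whereas it now also separates compound 3 from a second compound carrying a heavier halogen; the steps joining compound 4 to compound 1 and compound 2 cannot be read, as both ends of each are limits. Within the data shown here, compound 3 is thus the only compound with a real number, and every comparison here rests on that single value: the limit of > 100000 nM in this assay, at which 3 of the 4 values shown sit.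

The step from compound 3 to compound 4 swaps the halogen and moves it on the ring at once, so the compounds shown cannot tell which of the two matters; a 3-bromophenyl or a 4-chlorophenyl group would pull them apart. From the compounds shown here alone, it also remains open whether the number of compound 3 can be lowered further, for example by an amine or a carboxylic acid on this ring, or by a longer chain in place of the benzyl carbon.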